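Replacing the methoxyethylamino group on the shared core

A few compounds are considered here, and "the series" means these few. Any claim that something is new, unique, unknown or untested is made for them only; others in the source may bear on it.

Compound 1, `CCN(CC)c1nc(C)nc2c1ncn2-c1ccc(C(C)C)cc1Br`: 12.4 nM
Compound 2, `CCCCN(CCCC)c1nc(C)nc2c1ncn2-c1ccc(C(C)C)cc1Br`: 6.1 nM
Compound 3, `COCCNc1nc(C)nc2c1ncn2-c1ccc(C(C)C)cc1Br`: 210 nM

Of the compounds shown here, three sharing one core have been tested in an in vitro assay on 293-EBNA cells for binding affinity to corticotropin-releasing factor receptor 1 (Homo sapiens); on this read-out higher numbers stand for weaker inhibition and lower numbers for stronger inhibition. Compound 3 has the highest number of the three; its nearest neighbour is compound 1, as the step of a 17-fold higher number from compound 1 to compound 3 (1.23 log units; beyond the scatter) shows, and its furthest is compound 2, as the step of a 34-fold higher number from compound 2 to compound 3 (1.54 log units; beyond the scatter) shows. Between the two dialkylamino compounds the step of a 2.0-fold lower number from compound 1 to compound 2 (0.31 log units; beyond the scatter) is modest.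

Compound 4, `CCCC(CC)Nc1nc(C)nc2c1ncn2-c1ccc(C(C)C)cc1Br`, is not yet measured in this assay. It differs from compound 3 in one place: 1-ethylbutyl in place of 2-methoxyethyl on a nitrogen on an aromatic ring. Both steps that bear on this change, from compound 1 and from compound 2 to compound 3, were large, and each moved from an alkyl-bearing nitrogen to the (2-methoxyethyl)amino compound with a marked rise in the number. Compound 4 returns to an alkyl group on that nitrogen, so a large fall is expected, though a secondary amine has not been paired with a plain alkyl group here. Compound 4 is estimated at 10 nM, within 3 nM to 40 nM, an expected step of a 21-fold lower number from compound 3 to compound 4 (1.32 log units; beyond the scatter).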

Compound 4, inhibition constant: 4.4 nM
The estimate for compound 4 lay 2.3-fold (0.36 log units) above the measured number; the range from low to high includes it.
By their numbers in this assay, from the lowest: compounds 4 and 2 (each within the scatter of the next); then compound 1; then compound 3.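

Going by these compounds alone, at this position, a nitrogen on an aromatic ring, compound 3 and compound 4 each carry only one group on the nitrogen. The change of that group alone, 1-ethylbutyl in place of 2-methoxyethyl, gives a large step in this assay (a 48-fold lower number from compound 3 to compound 4 (1.68 log units; beyond the scatter)). A single branched alkyl group also does as well as two butyl chains (a 1.4-fold lower number from compound 2 to compound 4 (0.14 log units; within the scatter)), a step within the scatter. Against two ethyl groups it gives a modest step beyond the scatter (a 2.8-fold lower number from compound 1 to compound 4 (0.45 log units; beyond the scatter)).

The compounds shown leave open whether the oxygen of 2-methoxyethyl or the size and branching of the group sets the step, which a straight butyl chain or a cyclopentyl ring on the same nitrogen could help separate. Nothing available here explains the step from 2-methoxyethyl to 1-ethylbutyl.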